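Isopropyl for propyl on a cyano-bearing anilide

A few compounds are considered here, and "the series" means these few. Any claim that something is new, unique, unknown or untested is made for them only; others in the source may bear on it.

Measured in a functional assay on MCF7 cells (Homo sapiens) for antiproliferative activity, read by MTT assay, with a stated time of 72 h (a lower number here means a stronger inhibitor, a higher number a weaker inhibitor), so far:
Compound 1 `CC(C)/C=C/C(=O)Nc1cccc(Oc2nc(Nc3ccn(C)n3)nc3c2CSCC3)c1` gives > 50000 nM as a limit
Compound 2 `CCC/C=C/C(=O)Nc1cccc(Oc2nc(Nc3cccc(C#N)c3)nc3c2CSCC3)c1` gives 15300 nM as a number

Within the data shown here, of the two results in this assay, only one is an actual number. Compound 1 gives > 50000 nM as a limit of the measurement and not as a number. Among the measured compounds shown here, compound 2 stands alone with 15300 nM as the only true value available, so it has no measured neighbour to be ranked against.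

Compound 3 `CC(C)/C=C/C(=O)Nc1cccc(Oc2nc(Nc3cccc(C#N)c3)nc3c2CSCC3)c1` has not yet been measured. It differs from compound 2 by isopropyl in place of propyl on a double-bonded chain carbon bound to a double-bonded chain carbon in the chain, where pent-1-en-1-yl becomes 3-methylbut-1-en-1-yl. The two have the same atoms, joined differently. For the measured compounds named here, no measured pair shows this change on its own, so the expectation has a single anchor, compound 2 with 15300 nM as its value. In this assay the expected result is a 1.1-fold higher number from compound 2 to compound 3 (0.05 log units; within the scatter) as a step, with no shift beyond the usual scatter and only a slight lean towards weaker inhibition. In this assay compound 3 is estimated at 17000 nM with an expected range from 7000 nM to 42000 nM as its two ends.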

Compound 3, half-maximal inhibitory concentration: 29600 nM
Estimate against measurement, compound 3: 1.7-fold (0.24 log units) below, and the stated range covers the measured number.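

In this assay, isopropyl in place of propyl on a double-bonded chain carbon bound to a double-bonded chain carbon gives a 1.9-fold higher number from compound 2 to compound 3 (0.29 log units; within the scatter), so this first change at the position that can be read between two actual numbers does not move the result beyond the usual scatter of repeated measurements. Among these compounds, with the isopropyl side held fixed, compound 3 also allows the first comparison at the other varied place, 3-cyanophenyl in place of 1-methyl-1H-pyrazol-3-yl on a nitrogen on an aromatic ring, which gives an at least 1.6-fold lower number from compound 1 to compound 3 (0.22 log units; that floor lies within the scatter) and so shows no shift beyond the scatter even at its floor. From the compounds shown here alone, that step can be read only as a floor, and its true size stays unknown, because the result for compound 1 is a limit and not a number: the limit of > 50000 nM in this assay, at which 1 of the 3 values shown sits.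

The compounds shown leave open whether a longer chain, a cyclopropyl group or an amine in place of propyl would shift the number beyond the scatter. They also leave open how a group such as 3-chlorophenyl or 3-methoxyphenyl on that nitrogen would compare with 3-cyanophenyl.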